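Swapping fluoro for cyano on a sulfone

This account rests on a few compounds, and the source may have more. Where it says the series, first, only, none or still open, it means among the compounds named here.

Measured so far in a functional assay on MT4 cells (Homo sapiens) for cytotoxicity; a lower number here means a stronger inhibitor, a higher number a weaker inhibitor:
Compound 1 `N#Cc1c(N)cccc1S(=O)(=O)c1ccccc1Br`: 40000 nM
Compound 2 `N#Cc1c(N)cccc1S(=O)(=O)c1ccccc1F`: 57000 nM

Among the compounds with values here, compound 2 stands level with the only other measured compound: compound 2 gives 57000 nM and compound 1 gives 40000 nM, two numbers that repeat measurements could not tell apart. The next compound to be tested is compound 3 `N#Cc1ccccc1S(=O)(=O)c1cccc(N)c1C#N`. It keeps the shared core and has cyano in place of fluoro on an aromatic carbon, ortho to a large group (cyano in place of fluoro on an aromatic carbon).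

Within the data shown here, only one measured step bears on this change. It concerns the same place on the molecule: a 1.4-fold higher number from compound 1 to compound 2 (0.15 log units; within the scatter), with fluoro in place of bromo on an aromatic carbon. Among the measured compounds shown here, a single step between two compounds is thin evidence, and no measured compound other than compound 3 carries a second cyano group. Even so, that step gives no reason to expect a shift, so no change beyond the scatter is expected in this assay, in either direction. The estimated change is a 1.3-fold lower number from compound 2 to compound 3 (0.10 log units; within the scatter). For compound 3 the expected value is 45000 nM, with an estimated range of 15000 nM to 120000 nM.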

Compound 3, half-maximal inhibitory concentration: > 200000 nM
Compound 3 gave a limit, no number (the forecaster's own chance of this, stated with the estimate: 20%); middle value at least 4.4-fold (0.64 log units) away from the limit.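

In this assay compound 3 gives > 200000 nM, which is a limit of the assay and not a number. Before this result, the only change at this position, fluoro in place of bromo, stayed within the scatter, with a 1.4-fold higher number from compound 1 to compound 2 (0.15 log units; within the scatter), so the position could have seemed indifferent to what sits on it, but cyano gives a change beyond the scatter, with an at least 3.5-fold higher number from compound 2 to compound 3 (0.54 log units; beyond the scatter) and with an at least 5.0-fold higher number from compound 1 to compound 3 (0.69 log units; beyond the scatter). On these data alone, both of these new steps point to a weaker inhibitor, but they are minimum sizes rather than exact ones, and the true value for compound 3 stays unknown, as the reading itself shows: the limit of > 200000 nM in this assay, at which 1 of the 3 values shown sits.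

With only bromo, fluoro and cyano shown at this position, it remains open whether this loss of inhibition is particular to cyano or would also appear with another group there, such as an amine, a carboxylic acid or a methoxy group. As far as these compounds go, it also remains open whether cyano would give a step of similar size on a core other than the shared core of these three compounds.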